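Swapping the anilide ring of a quinoline ether amide

A few compounds are considered here, and "the series" means these few. Any claim that something is new, unique, unknown or untested is made for them only; others in the source may bear on it.

Measured so far:
- compound 1, `COc1ccc2nc(C)cc(OCC(=O)Nc3cc(C)ccc3C)c2c1`: 45500 nM
- compound 2, `COc1ccc2nc(C)cc(OCC(=O)Nc3cc(OC)c(Cl)cc3OC)c2c1`: 3000 nM

Going by the values given here, in a physicochemical assay for solubility, in phosphate buffer, measured as kinetic solubility, with a stated time of 1 h, at pH 7.4 (a lower number here means a less soluble compound, a higher number a more soluble compound), compound 1 gives 45500 nM, the higher of the two numbers known; compound 2 sits well below it, with a gap that is beyond the usual scatter. Among the compounds with values here, the two share a core and differ only in the ring carried on the amide nitrogen, but no single-point step between them is on hand, so their values show only that this ring matters.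

Compound 3, `COc1ccc2nc(C)cc(OCC(=O)Nc3ccc(Cl)cc3)c2c1`, is not yet measured. It differs from compound 1 by one change: 4-chlorophenyl in place of 2,5-dimethylphenyl on an amide-type nitrogen. Within the data shown here, with no measured step of this kind to lean on, the expectation is a modest decrease in this assay from compound 1 to compound 3, near the edge of the scatter rather than clearly beyond it. For compound 3 the estimated step is a 2.1-fold lower number from compound 1 to compound 3 (0.32 log units; beyond the scatter), giving an expected solubility of 22000 nM, within 6000 nM to 60000 nM.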

Compound 3, solubility: 9000 nM
Estimate against measurement, compound 3: 2.4-fold (0.39 log units) above; the measured number falls inside the stated range.
By their numbers in this assay, from the lowest: compound 2; then compound 3; then compound 1.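

In this assay, going by these compounds alone, putting 4-chlorophenyl in place of 2,5-dimethylphenyl on the amide-type nitrogen gives a 5.1-fold lower number from compound 1 to compound 3 (0.70 log units; beyond the scatter) and so attaches a size to a single change at this position for the first time. Within the data shown here, the earlier pair showed only that the ring carried here matters, whereas this step shows that exchanging one aromatic ring of carbon for another is enough to move the number beyond the scatter, with neither group carrying a net charge or any counted hydrogen-bond donor or acceptor. No measurement on hand gives a reason for this drop.

The step replaces the whole group at once, so the separate contributions of the chlorine and the two methyl groups remain unresolved. Also open, going by these compounds, is where the number in this assay would fall with an amine or a carboxylic acid on this ring.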